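The compounds below may be only part of what the source reports. "The series", "measured", "known", "first", "only" and "open" are said of these compounds alone.

Measured so far in a physicochemical assay for solubility, using the shake flask method, at pH 6.5; a higher number here means a more soluble compound, a lower number a less soluble compound:
- compound 1 `CC(C)(C)OC(=O)N[C@H]1CCCCC/C=C\[C@@H]2C[C@@]2(C(=O)NS(=O)(=O)C2CC2)NC(=O)[C@@H]2C[C@@H](OC(=O)N3CCc4ccccc4C3)CN2C1=O`: 812 ug/mL
- compound 2 `CC(C)(C)OC(=O)N[C@H]1CCCCC/C=C\[C@@H]2C[C@@]2(C(=O)NS(=O)(=O)C2CC2)NC(=O)[C@@H]2C[C@@H](OC(=O)N3Cc4ccccc4C3)CN2C1=O`: 702 ug/mL

Going by the values given here, only two numbers are known, and compound 2 cannot be separated from the other one: the data show a 1.2-fold lower number from compound 1 to compound 2 (0.06 log units; within the scatter).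

Compound 3 `CN(C)S(=O)(=O)NC(=O)[C@@]12C[C@H]1/C=C\CCCCC[C@H](NC(=O)OC(C)(C)C)C(=O)N1C[C@H](OC(=O)N3Cc4ccccc4C3)C[C@H]1C(=O)N2` keeps the rest of compound 2 and carries one change, dimethylamino in place of cyclopropyl on a sulfonyl sulfur. Among the compounds with values here, no measured step touches that place. Within the data shown here, the one step available, a 1.2-fold lower number from compound 1 to compound 2 (0.06 log units; within the scatter), concerns a group on a carbonyl carbon, so it bears on this change only indirectly and gives no direction. The estimate therefore starts from compound 2 at 702 ug/mL, with a wide margin for the untested change. The expected move is a 1.3-fold lower number from compound 2 to compound 3 (0.11 log units; within the scatter), which means no expected step beyond the scatter. For compound 3 the expected value in this assay is 550 ug/mL, with an estimated range from 180 ug/mL to 1300 ug/mL.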

Compound 3, solubility: 165 ug/mL
The estimate for compound 3 lay 3.3-fold (0.52 log units) above the measured number; measured number below the stated range.
By their numbers in this assay, from the lowest: compound 3; then compounds 2 and 1 (each within the scatter of the next).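

The group on the sulfonyl sulfur matters in this assay: dimethylamino in place of cyclopropyl gives a 4.3-fold lower number from compound 2 to compound 3 (0.63 log units; beyond the scatter) and this modest step stands apart from the earlier change on a carbonyl carbon, which gave a 1.2-fold lower number from compound 1 to compound 2 (0.06 log units; within the scatter) and could not be told from scatter. The two groups have the same heavy-atom count, so that count alone does not separate them; what differs is that dimethylamino has a nitrogen and no ring, while cyclopropyl is an all-carbon ring. Nothing measured here says why the number falls.

A single pair cannot show whether the nitrogen or the loss of the ring matters more. An open-chain propyl group would have no ring and no nitrogen, while azetidine would have both, so either on the sulfonyl sulfur could help separate the two, and the same change on compound 1 remains an open comparison.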